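A few compounds are considered here, and "the series" means these few. Any claim that something is new, unique, unknown or untested is made for them only; others in the source may bear on it.

In a functional assay on HCT-116 cells (Homo sapiens) for antiproliferative activity, read by sulforhodamine B assay, with a stated time of 48 h (on this read-out lower numbers stand for stronger inhibition and higher numbers for weaker inhibition), three compounds have been measured so far. Compound 1 (`COc1cccc(/C=C/C(=O)c2c(O)cc(OC)cc2OC)c1`) gives 3100 nM, compound 2 (`COc1cc(OC)c(C(=O)/C=C/c2ccc(OC)c(OC)c2)c(OCC=C(C)C)c1`) gives 5700 nM, and compound 3 (`COc1cc(OC)c(C(=O)/C=C/c2ccc(F)cc2)c(OCC=C(C)C)c1`) gives 3200 nM. Compound 3 stands within the usual scatter of both others, so these numbers do not rank it against them.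

Compound 4 (`COc1cccc(/C=C/C(=O)c2c(OC)cc(OC)cc2OCC=C(C)C)c1`) keeps the rest of compound 3 and changes one group: 3-methoxyphenyl in place of 4-fluorophenyl on a double-bonded chain carbon bound to a double-bonded chain carbon.

Among the measured compounds shown here, only one measured step concerns that same place. It is a 1.8-fold lower number from compound 2 to compound 3 (0.25 log units; within the scatter), with 4-fluorophenyl in place of 3,4-dimethoxyphenyl, and it lies within the scatter. A single step is thin evidence, but it gives no sign that a change at this place moves the number measurably. Compound 1 also carries 3-methoxyphenyl and gives 3100 nM, yet it differs from compound 4 elsewhere too, so it is only a loose guide.

No step beyond the scatter is therefore expected in this assay, and no firm direction can be given. The expected step is a 1.1-fold higher number from compound 3 to compound 4 (0.04 log units; within the scatter). For compound 4 the estimated value is 3500 nM, with an expected range from 1600 nM to 7500 nM.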

Compound 4, half-maximal inhibitory concentration: 7700 nM
Compound 4: the middle estimate sits 2.2-fold (0.34 log units) below what was measured, and the stated range ends below it.
By their numbers in this assay, from the lowest: compounds 1, 3, 2 and 4 (each within the scatter of the next, the first and the last beyond it).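

In this assay, the group on the double-bonded chain carbon can now be seen to affect the number: the step of a 2.4-fold higher number from compound 3 to compound 4 (0.38 log units; beyond the scatter) is modest but lies beyond the scatter, which the earlier step at this place did not. Not every change to this group registers, however: the step of a 1.4-fold higher number from compound 2 to compound 4 (0.13 log units; within the scatter), with hydrogen in place of methoxy on an aromatic carbon, stays within the scatter, so 3-methoxyphenyl and 3,4-dimethoxyphenyl cannot be told apart here. A second place also registers, since the step of a 2.5-fold higher number from compound 1 to compound 4 (0.40 log units; beyond the scatter), with 3-methylbut-2-en-1-yl in place of hydrogen on an oxygen on an aromatic ring and 3-methoxyphenyl kept, lies beyond the scatter as well.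

No measurement among these results accounts for either modest step. On these data alone, it remains open how an aromatic ring bearing a dimethylamino group or a carboxylic acid would behave at the first place, and how a longer chain, such as a decyl chain, would behave on that oxygen.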